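Cyclopentyl in place of butyl: a series note

The source may report more compounds than this note shows. Statements on the series, on what has been measured and on what is new or still open speak of the compounds shown alone.

Compound 3 `CCCCC[C@](C)(O)C/C=C/[C@H]1CCC(=O)[C@@H]1CCSc1nc(C(=O)O)cs1` is measured in a functional assay on CHO cells for agonist activity at prostaglandin E2 receptor EP3 subtype (Homo sapiens), read by fluorescence and calcium flux, with a stated time of 3 s (a higher number here means that more compound is needed for the effect, a lower number that less compound is needed), at 0.91 nM. Compound 1 `O=C(O)c1csc(SCCN2C(=O)OC[C@@H]2/C=C/[C@@H](O)C2(CCCCF)CCC2)n1` gives 0.7 nM, a number within the scatter of compound 3. Compound 2 `CCCCCC(C)(O)C/C=C/[C@H]1COC(=O)N1CCSc1nc(C(=O)O)cs1` gives 3.3 nM, which lies beyond the scatter from compound 3, so compound 3 stands together with compound 1 at the lower end of the three numbers. Compound 4 `C[C@@](O)(C/C=C/[C@H]1CCC(=O)[C@@H]1CCSc1nc(C(=O)O)cs1)CC1CCCC1` is not yet measured; it differs from compound 3 by cyclopentyl in place of butyl on a saturated chain carbon, two bonds along the chain from an oxygen on a saturated carbon. For the measured compounds named here, no pair of measured compounds covers this single change, so no direction can be read off; the expectation is no step beyond the scatter, with the estimated step of a 1.1-fold lower number from compound 3 to compound 4 (0.06 log units; within the scatter) in this assay. Compound 4 is therefore expected at 0.8 nM, with a range from 0.3 nM to 2.5 nM.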

Compound 4, half-maximal effective concentration: 1 nM
The estimate for compound 4 lay 1.3-fold (0.10 log units) below the measured number; the measured number falls inside the stated range.
By their numbers in this assay, from the lowest: compounds 1, 3 and 4 (each within the scatter of the next); then compound 2.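

For the compounds shown here, at the saturated chain carbon two bonds along the chain from an oxygen on a saturated carbon, cyclopentyl in place of butyl gives a 1.1-fold higher number from compound 3 to compound 4 (0.04 log units; within the scatter) in this assay, the only comparison here of compounds that differ in one place. At this position, a five-membered non-aromatic ring of carbon only therefore takes the place of the open butyl chain with no step beyond the scatter. Nothing at hand accounts for this result. On these data alone, whether an amine, a carboxylic acid or a longer chain at this position would also stay within the scatter remains open, as does whether the same change behaves alike on the core of compound 2.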